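From 3-chlorophenyl to 5-nitrothiophen-3-yl in a growth inhibition test

The compounds below may be only part of what the source reports. "The series", "measured", "known", "first", "only" and "open" are said of these compounds alone.

compound 1 `Cc1cc(=O)c2c(O)cc(OC/C=C/c3ccccc3)c([C@H]3CCN(C)C[C@H]3O)c2o1`: 11%
compound 2 `Cc1cc(=O)c2c(O)cc(OCc3ccco3)c([C@H]3CCN(C)C[C@H]3O)c2o1`: 7%
compound 3 `Cc1oc2c([C@H]3CCN(C)C[C@H]3O)c(O)cc(O)c2c(=O)c1C(O)c1cccc(Cl)c1`: 2%

All three compounds were tested in a functional assay on MIA PaCa-2 cells (Homo sapiens) for inhibition, read by MTT assay, with a stated time of 48 h, tested at 10 uM; on this read-out higher numbers stand for more inhibition of growth at the one concentration tested and lower numbers for less inhibition of growth. Compound 3 gives 2%, a value within the usual scatter of those of compound 1 and compound 2, so the three cannot be ranked against one another.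

Compound 4 `Cc1oc2c([C@H]3CCN(C)C[C@H]3O)c(O)cc(O)c2c(=O)c1C(O)c1csc([N+](=O)[O-])c1` differs from compound 3 in one place, on a saturated chain carbon bound to an aromatic carbon and an oxygen on a saturated carbon: 5-nitrothiophen-3-yl in place of 3-chlorophenyl on a saturated chain carbon bound to an aromatic carbon and an oxygen on a saturated carbon.

Going by the values given here, no measured pair changes the group at this place, so the evidence is indirect. Among the compounds with values here, the only measured step, a number 4 percentage points lower from compound 1 to compound 2 (within the scatter), also swaps one group carrying an aromatic ring for another, but it does so elsewhere on the molecule. It offers a weak hint that such a swap need not shift the number much. No change beyond the scatter is therefore expected in this assay. Within the data shown here, the 5-nitrothiophen-3-yl group has no measured precedent in this set, so the range is left wider on the upper side.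

The estimated change is a number 5 percentage points higher from compound 3 to compound 4 (within the scatter). The expected value for compound 4 is 7%, with an estimated range from 0% to 22%.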

Compound 4, percent growth inhibition at one concentration: 41%
Compound 4: the middle estimate sits 34 percentage points below what was measured, outside the stated range (above it).
By their numbers in this assay, from the lowest: compounds 3, 2 and 1 (each within the scatter of the next); then compound 4.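

In this assay, going by these compounds alone, 5-nitrothiophen-3-yl in place of 3-chlorophenyl gives a number 39 percentage points higher from compound 3 to compound 4 (beyond the scatter), the only step so far that lies beyond the scatter. Within the data shown here, this shows that the group on this saturated chain carbon can strongly change growth inhibition on these cells, something the earlier compounds, all within the scatter of one another, could not show. The swap alters several things at once, replacing a six-membered aromatic ring of carbon only with a five-membered aromatic ring holding a hetero atom, removing the chlorine and bringing in a nitro group, and nothing available here links the rise to any one of these changes or explains it.

The compounds shown leave open whether the rise goes with the nitro group or with the thiophene ring, and a plain thiophen-3-yl or a 3-nitrophenyl group at this place would separate the two. Also open, as far as these compounds go, is whether an amine in place of the nitro group would keep the number up, and how compound 4 would behave at concentrations other than the one tested.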